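The compounds below may be only part of what the source reports. "The series", "measured", "known", "first", "only" and "open" are said of these compounds alone.

Measured so far:
- compound 1, `CCCc1cnc2c(C#N)c(N3CCN(c4ncccn4)CC3)ccn12`: 248%
- compound 2, `CCCc1cnc2c(C#N)c(N3CCN(c4nc(C)cc(C)n4)CC3)ccn12`: 179%

Compound 2 stands lowest of the two numbers in a functional assay on CHO cells with metabotropic glutamate receptor 2 (Homo sapiens) as the target, read by GTPgammaS binding; a lower number here means a smaller maximal response, a higher number a larger maximal response; its nearest neighbour is compound 1, which lies higher by a number 69 percentage points lower from compound 1 to compound 2 (beyond the scatter), a step that carries a 4,6-dimethylpyrimidin-2-yl in place of pyrimidin-2-yl on an amine nitrogen in a ring.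

Compound 3, `CCCc1cnc2c(C#N)c(N3CCN(c4ccccc4)CC3)ccn12`, is not yet measured. Going by the values given here, it differs from compound 2 by phenyl in place of 4,6-dimethylpyrimidin-2-yl on an amine nitrogen in a ring, the only change being the group on that ring nitrogen. Among the compounds with values here, no measured pair exchanges a pyrimidine for a carbon-only ring at this position. Within the data shown here, the one step in hand shows that the group on this nitrogen can move the maximal response by a large amount, since going from compound 1 to compound 2 gave a number 69 percentage points lower from compound 1 to compound 2 (beyond the scatter). Removing the two methyl groups along with both ring nitrogens leaves the direction uncertain, so the expectation for compound 3 is a step of about a number 26 percentage points higher from compound 2 to compound 3 (beyond the scatter) in this assay, a moderate rise, with wide uncertainty.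

Estimated for compound 3: 205%, range 130% to 280%.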

Compound 3, largest response reached (Emax), in percent of the reference or control that the assay uses: 241%
The estimate for compound 3 lay 36 percentage points below the measured number; measured number inside the range.
By their numbers in this assay, from the lowest: compound 2; then compounds 3 and 1 (each within the scatter of the next).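

In this assay, phenyl in place of 4,6-dimethylpyrimidin-2-yl on the ring nitrogen gives a number 62 percentage points higher from compound 2 to compound 3 (beyond the scatter), while phenyl in place of pyrimidin-2-yl gives a number 7 percentage points lower from compound 1 to compound 3 (within the scatter). Across these three compounds, the pyrimidin-2-yl and phenyl rings are therefore not told apart by this read-out, so a carbon-only ring and a ring with 2 nitrogen atoms can both sit at this position with the maximal response staying within the scatter, and compound 2 alone stands apart. The lower response is thus tied to the 4,6-dimethylpyrimidin-2-yl group as a whole and not to the presence of a pyrimidine ring, though nothing at hand explains the shift at this position.

On these data alone, whether the two methyl groups alone carry the drop remains open: a 4-methylpyrimidin-2-yl group would show if one methyl is enough, and a 3,5-dimethylphenyl group would show if the same fall appears on a carbon-only ring. Also open, as far as these compounds go, is whether an aromatic ring is needed on this nitrogen at all, which a cyclohexyl or an acetyl group would test in this assay.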